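A few compounds are considered here, and "the series" means these few. Any claim that something is new, unique, unknown or untested is made for them only; others in the source may bear on it.

Measured in a functional assay on PC-3 cells (Homo sapiens) for inhibition, read by colorimetric assay and MTT assay, with a stated time of 72 h; a lower number here means a stronger inhibitor, a higher number a weaker inhibitor:
Compound 1 `COc1ccccc1-c1cnc(OCC(F)(F)C(F)(F)C(F)(F)C(F)(F)C(F)(F)F)n1C`: 72000 nM
Compound 2 `C=CCCCCOc1ncc(I)n1C`: > 100000 nM

Compound 2 gives no number in this assay, only a limit, > 100000 nM. That reading is the limit of > 100000 nM in this assay, at which 1 of the 2 values shown sits. Compound 1 does give a number, 72000 nM, but no single change links it to compound 2.

Compound 3 `C=CCCCCOc1nccn1C` differs from compound 2 at one place, with hydrogen in place of iodo on an aromatic carbon. Within the data shown here, no measured pair shows what this exchange does in this assay, and compound 2 offers only a limit to start from. No clear gain in inhibition is therefore expected, and any shift is expected to stay small, with no firm direction. The expected change is a step that the limit leaves unreadable from compound 2 to compound 3. For compound 3 the estimated value is 150000 nM, with an expected range from 50000 nM to 400000 nM.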

Compound 3, half-maximal inhibitory concentration: > 100000 nM
Compound 3: a limit, no number; the forecaster's own chance of this, stated with the estimate: 75%; the middle value is on the limit's open side.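

In this assay, among these compounds, compound 2 and compound 3 each give a limit and not a number, so no step between them can be read: the limit of > 100000 nM in this assay, at which 2 of the 3 values shown sit.

The compounds shown leave open whether hydrogen in place of iodo on an aromatic carbon changes inhibition at all.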